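A Carbonyl-Side Ring Exchange Starting from Compound 2

The compounds below may be only part of what the source reports. "The series", "measured", "known", "first", "only" and "open" are said of these compounds alone.

compound 1 `O=C(NCc1ccc(S(=O)(=O)c2cc(F)cc(F)c2)cn1)c1cc2cnccc2[nH]1`: 39 nM
compound 2 `CC(C)n1cc(S(=O)(=O)c2ccc(CNC(=O)c3cc4cnccc4[nH]3)nc2)cn1`: 84 nM

In an assay for inhibition of Nicotinamide phosphoribosyltransferase (Homo sapiens), with stated times of 15 min and 30 min (a higher number here means a weaker inhibitor, a lower number a stronger inhibitor), compound 1 gives 39 nM and compound 2 gives 84 nM, so compound 2 holds the higher of the two numbers. Among the compounds with values here, the one measured step, a 2.2-fold higher number from compound 1 to compound 2 (0.33 log units; beyond the scatter), concerns the group on the sulfonyl sulfur and not the carbonyl carbon. Compound 3 `CC(C)n1cc(S(=O)(=O)c2ccc(CNC(=O)c3cc4ccncc4s3)nc2)cn1` differs from compound 2 by a group of 9 heavy atoms (7 carbon, 1 nitrogen, 1 sulfur; one five-membered aromatic ring with 1 hetero atom, one six-membered aromatic ring with 1 hetero atom) in place of a group of 9 heavy atoms (7 carbon, 2 nitrogen; one five-membered aromatic ring with 1 hetero atom, one six-membered aromatic ring with 1 hetero atom), on a carbonyl carbon. Within the data shown here, no measured step bears on a change at this position, so the expectation rests on the change alone. A modest weakening is expected for compound 3, a 2.4-fold higher number from compound 2 to compound 3 (0.38 log units; beyond the scatter), with an estimate in this assay of 200 nM, between 60 nM and 700 nM.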

Compound 3, half-maximal inhibitory concentration in the Nicotinamide phosphoribosyltransferase assay: 7 nM
Compound 3: the middle estimate sits 29-fold (1.46 log units) above what was measured, outside the stated range (below it).
By their numbers in the Nicotinamide phosphoribosyltransferase assay, from the lowest: compound 3; then compound 1; then compound 2.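

In the Nicotinamide phosphoribosyltransferase assay the exchange on the carbonyl carbon gives a 12-fold lower number from compound 2 to compound 3 (1.08 log units; beyond the scatter), a larger move than the change on the sulfonyl sulfur gave in a 2.2-fold higher number from compound 1 to compound 2 (0.33 log units; beyond the scatter), and the entering group has 0 hydrogen-bond donors. In a physicochemical assay for solubility, measured as kinetic solubility, with a stated time of 24 h, at pH 7.4 (a lower number here means a less soluble compound, a higher number a more soluble compound), the same exchange gives a 1.1-fold lower number from compound 2 to compound 3 (0.04 log units; within the scatter), with compound 2 at 46000 nM and compound 3 at 42000 nM, so this read-out does not separate the pair. Nothing at hand accounts for the size of the step.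

Still open, going by these compounds, is whether 3,5-difluorophenyl on the sulfonyl sulfur would combine with this carbonyl-side group, and whether an amine on that group would keep the number this low.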